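The source may report more compounds than this note shows. Statements on the series, on what has been measured and on what is new or still open speak of the compounds shown alone.

Three compounds have been measured in a functional assay on HCT-116 cells (Homo sapiens) for inhibition, read by CCK-8 assay, with a stated time of 72 h, tested at 2 uM (on this read-out lower numbers stand for less inhibition of growth and higher numbers for more inhibition of growth at the one concentration tested), so far:

- compound 1 `COc1ccc(SCc2ccc(C(=O)Nc3ccccc3N)cc2)cc1` gives 73.3%
- compound 2 `Nc1ccccc1NC(=O)/C=C/c1ccc(CSCCc2ccccc2)cc1` gives 18%
- compound 3 `COc1ccc(SCc2ccc(C(=O)Nc3ccccc3N)cc2)cc1OC` gives 33.6%

Compound 1 has the highest number of the three, clear of the scatter against both others. Compound 4 `Nc1ccccc1NC(=O)c1ccc(CSc2ccc(Cl)cc2)cc1` has chloro in place of methoxy on an aromatic carbon, para to a large group: chloro in place of methoxy on an aromatic carbon. Compound 2 differs from compound 1 in more than one place, so it offers no clean comparison. Among the compounds with values here, the one measured step that bears on this change is a number 39.7 percentage points lower from compound 1 to compound 3 (beyond the scatter), which adds a methoxy on the same ring and shows that this ring can tolerate change poorly. Within the data shown here, a moderate drop is therefore expected, though no measured compound carries chloro. The expected change is a number 15.3 percentage points lower from compound 1 to compound 4 (beyond the scatter), and this size is uncertain. The estimated value for compound 4 is 58%, with an expected range from 30% to 82%.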

Compound 4, percent growth inhibition at one concentration: 17.5%
Beside the measured number, compound 4's estimate is 40.5 percentage points above it, and the stated range ends above it.
By their numbers in this assay, from the lowest: compounds 4 and 2 (each within the scatter of the next); then compound 3; then compound 1.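

In this assay, replacing 4-methoxyphenyl with 4-chlorophenyl gives a number 55.8 percentage points lower from compound 1 to compound 4 (beyond the scatter), so the result for compound 1 depends on what sits at this place, para to a large group. Earlier, only the addition of a second methoxy had been seen, with a number 39.7 percentage points lower from compound 1 to compound 3 (beyond the scatter); now exchanging the methoxy itself also lowers the number. No measurement here explains this drop.

As far as these compounds go, whether an ethoxy, a hydroxy or an amine at this place would keep the number high remains open. So does whether any group can match methoxy here.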